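From 3-Methoxyphenyl to 2-Chlorophenyl on the Amide Nitrogen

The source may hold more compounds than are shown below. What is called first, only, known or untested is meant among the compounds shown, and "the series" means these compounds.

Compound 1 `COc1ccc2c(=O)c(/C=C/C(=O)Nc3cc(C)ccc3C)coc2c1`: 58400 nM
Compound 2 `COc1ccc(CNC(=O)/C=C/c2coc3cc(OC)ccc3c2=O)cc1`: > 100000 nM, a limit of the assay
Compound 3 `COc1cccc(NC(=O)/C=C/c2coc3cc(OC)ccc3c2=O)c1`: 19200 nM

Three compounds share one core and differ only in the group on the amide-type nitrogen. Each was tested in a functional assay on HeLa cells (Homo sapiens) for inhibition, read by MTT assay, with a stated time of 48 h; on this read-out higher numbers stand for weaker inhibition and lower numbers for stronger inhibition. Compound 3 gives the lowest of the two plain numbers measured; the step of a 3.0-fold lower number from compound 1 to compound 3 (0.48 log units; beyond the scatter) is modest but beyond the scatter. For compound 2 the assay reports only a limit, (the limit of > 100000 nM in this assay, at which 1 of the 3 values shown sits), so the step of an at least 5.2-fold lower number from compound 2 to compound 3 (0.71 log units; beyond the scatter) is known only as a floor, and the step of an at least 1.7-fold higher number from compound 1 to compound 2 (0.23 log units; that floor lies within the scatter) lies within the scatter.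

Compound 4 `COc1ccc2c(=O)c(/C=C/C(=O)Nc3ccccc3Cl)coc2c1` differs from compound 3 in one place: 2-chlorophenyl in place of 3-methoxyphenyl on an amide-type nitrogen. Of the measured steps, the one from a substituted phenyl to another substituted phenyl bears most directly, and it was modest. Compound 4 keeps a phenyl directly on the nitrogen, as compounds 1 and 3 do, but like the 2,5-dimethylphenyl of compound 1 it carries no hydrogen-bond acceptor, so a modest move back toward the number of compound 1 is expected, a 1.8-fold higher number from compound 3 to compound 4 (0.26 log units; within the scatter). Compound 4 is therefore estimated at 35000 nM, with a range from 12000 nM to 100000 nM.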

Compound 4, half-maximal inhibitory concentration: 22400 nM
Estimate against measurement, compound 4: 1.6-fold (0.19 log units) above; the range from low to high includes it.
By their numbers in this assay, from the lowest: compounds 3 and 4 (each within the scatter of the next); then compound 1. At a limit, above all of these: compound 2.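

Replacing the 3-methoxyphenyl, which has 1 hydrogen-bond acceptor, with the 2-chlorophenyl, which has none, barely registers in this assay: the result is a 1.2-fold higher number from compound 3 to compound 4 (0.07 log units; within the scatter), so at this position on the amide-type nitrogen these two different substituted phenyl groups cannot be told apart. Losing the acceptor is also not enough to account for the number of compound 1, whose 2,5-dimethylphenyl likewise carries no acceptor, since the change to the 2-chlorophenyl gives a 2.6-fold lower number from compound 1 to compound 4 (0.42 log units; beyond the scatter), and substituted phenyl groups without an acceptor therefore need not behave alike. Compound 2 is known only as a limit, so an at least 4.4-fold lower number from compound 2 to compound 4 (0.64 log units; beyond the scatter) is a floor and its true size stays unknown: the limit of > 100000 nM in this assay, at which 1 of the 4 values shown sits.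

The compounds shown leave open how a plain phenyl on this nitrogen would compare, and so whether the chlorine, the methoxy or the methyl groups contribute anything at all. They also leave open whether a phenyl bearing an amine or a carboxylic acid, or a longer chain on the nitrogen, would fit the same picture.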